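Fluoro to methoxy on a growth inhibition series

The compounds below may be only part of what the source reports. "The series", "measured", "known", "first", "only" and "open" are said of these compounds alone.

Compound 1 `Fc1ccc(-c2ccc(-c3ccc(-c4nc5ccccc5[nH]4)cc3)cc2)cc1`: 35600 nM
Compound 2 `COc1ccc(-c2ccc(-c3ccc(-c4nc5ccccc5[nH]4)cc3)cc2)cc1`: 100000 nM
Compound 3 `Oc1cccc2[nH]c(-c3ccc(-c4ccc(-c5ccc(F)cc5)cc4)cc3)nc12`: 22200 nM

All three values come from a functional assay on DWD cells (Homo sapiens) for inhibition, read by sulforhodamine B assay; on this read-out lower numbers stand for stronger inhibition of growth and higher numbers for weaker inhibition of growth. Compound 3 gives 22200 nM, the lowest number of the three, although a 1.6-fold lower number from compound 1 to compound 3 (0.21 log units; within the scatter), so it cannot be separated from compound 1. Its number is clearly lower than that of compound 2.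

The next compound to be tested is compound 4 `COc1ccc(-c2ccc(-c3ccc(-c4nc5c(O)cccc5[nH]4)cc3)cc2)cc1`, which differs from compound 3 in a single place: methoxy in place of fluoro on an aromatic carbon. The 4-fluorophenyl becomes 4-methoxyphenyl, para to a large group.

The same exchange has been measured once, on the compounds without the hydroxy group, where a 2.8-fold higher number from compound 1 to compound 2 (0.45 log units; beyond the scatter). That step is modest but real. The hydroxy step itself, in which a 1.6-fold lower number from compound 1 to compound 3 (0.21 log units; within the scatter), gives no sign that the two places interact, though a single pair cannot settle this. A step of similar size towards a higher number is therefore expected in this assay, and the expected change is a 2.7-fold higher number from compound 3 to compound 4 (0.43 log units; beyond the scatter). For compound 4 the estimated value is 60000 nM, with an expected range from 28000 nM to 100000 nM.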

Compound 4, concentration for 50% growth inhibition: 6400 nM
Compound 4: the middle estimate sits 9.4-fold (0.97 log units) above what was measured; measured number below the stated range.
By their numbers in this assay, from the lowest: compound 4; then compounds 3 and 1 (each within the scatter of the next); then compound 2.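

In this assay, the exchange of 4-fluorophenyl for 4-methoxyphenyl turns out to have no fixed effect at this position: with the hydroxy group on the core it gives a 3.5-fold lower number from compound 3 to compound 4 (0.54 log units; beyond the scatter), the opposite direction from the step seen without that group: the same change on two cores in this assay, a 2.8-fold higher number (0.45 log units; beyond the scatter) from compound 1 to compound 2 and a 3.5-fold lower number (0.54 log units; beyond the scatter) from compound 3 to compound 4, 9.7-fold (0.99 log units) apart, beyond the scatter of two such steps

The hydroxy group likewise matters far more alongside the methoxy, where adding it gives a 16-fold lower number from compound 2 to compound 4 (1.19 log units; beyond the scatter), than it did alongside the fluoro: the same change on two cores in this assay, a 1.6-fold lower number (0.21 log units; within the scatter) from compound 1 to compound 3 and a 16-fold lower number (1.19 log units; beyond the scatter) from compound 2 to compound 4, 9.7-fold (0.99 log units) apart, beyond the scatter of two such steps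

The two places therefore do not act independently in this set, and the effect of either change can be read only together with what stands at the other place.

What the compounds shown leave open is why the two places are coupled, since they show the step in values alone and give no measured property that would explain it. They also leave open whether the coupling is particular to this pair of groups, or whether an ethoxy or a chloro in place of the methoxy, or an amine in place of the hydroxy, would reverse the step in the same way.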